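Notes on compound 3: ((trifluoromethyl)sulfonyl)amino for methoxy

This account rests on a few compounds, and the source may have more. Where it says the series, first, only, none or still open, it means among the compounds named here.

Compound 1 `COc1cccc(OC)c1C(=O)/C=C/c1ccccc1` gives 1150 nM in a functional assay for inhibition, with Homo sapiens as the target; on this read-out lower numbers stand for stronger inhibition and higher numbers for weaker inhibition. Compound 2 `COc1ccccc1C(=O)/C=C/c1ccccc1` gives 2230 nM, the higher of the two numbers shown, though the step of a 1.9-fold higher number from compound 1 to compound 2 (0.29 log units; within the scatter) is within the scatter, so the pair is not separated. Compound 3 `O=C(/C=C/c1ccccc1)c1ccccc1NS(=O)(=O)C(F)(F)F` differs from compound 2 in this way: ((trifluoromethyl)sulfonyl)amino in place of methoxy on an aromatic carbon. Going by the values given here, the only measured step, a 1.9-fold higher number from compound 1 to compound 2 (0.29 log units; within the scatter), is also a change on an aromatic carbon and stayed within the scatter; no measured step involves the entering group. No shift beyond the scatter is therefore expected, and compound 3 is estimated at 2000 nM, range 600 nM to 7000 nM. The expected step of a 1.1-fold lower number from compound 2 to compound 3 (0.05 log units; within the scatter) is within the scatter.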

Compound 3, half-maximal inhibitory concentration: 5850 nM
Beside the measured number, compound 3's estimate is 2.9-fold (0.47 log units) below it, and the stated range covers the measured number.
By their numbers in this assay, from the lowest: compounds 1 and 2 (each within the scatter of the next); then compound 3.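

In this assay, going by these compounds alone, ((trifluoromethyl)sulfonyl)amino in place of methoxy on this aromatic carbon, ortho to a large group, gives the first step beyond the scatter, though a modest one: a 2.6-fold higher number from compound 2 to compound 3 (0.42 log units; beyond the scatter). Within the data shown here, the earlier change, a 1.9-fold higher number from compound 1 to compound 2 (0.29 log units; within the scatter), stayed within the scatter, so only this replacement separates two compounds on the read-out. No measurement offered here accounts for the shift.

Which part of the entering group goes with the weaker number remains open. An amine or a methylsulfonylamino group on the same carbon would help separate the contributions of the nitrogen, the sulfonyl and the trifluoromethyl.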